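Removing a Fluorine from the Benzyl Group

The source may hold more compounds than are shown below. What is called first, only, known or untested is meant among the compounds shown, and "the series" means these compounds.

Compound 1, `CN(C)/N=C1/CN(CC(=O)Nc2cccc(-c3cnn(C)c3)c2)C(=O)C(Cc2c(Cl)cccc2Cl)CN1`: 1200 nM; 16000 nM; 700 nM (3 entries)
Compound 2, `CN(C)/N=C1/CN(CC(=O)Nc2cccc(-c3cnn(C)c3)c2)C(=O)C(Cc2c(F)cccc2Cl)CN1`: 6000 nM

In an assay on isolated protein for inhibition of kallikrein-7 (Mus musculus), read by fluorescence, with stated times of 10 min and 30 min (a higher number here means a weaker inhibitor, a lower number a stronger inhibitor), compound 1 gives 1200 nM; 16000 nM; 700 nM (3 entries) across its repeated entries, and compound 2 gives 6000 nM. Within the data shown here, compound 2 carries only that one number, alongside a further entry for it that yielded no single value; the number it does have sits inside the span covered by the several entries of compound 1 in this assay, 1200 nM; 16000 nM; 700 nM (3 entries). Compound 3, `CN(C)/N=C1/CN(CC(=O)Nc2cccc(-c3cnn(C)c3)c2)C(=O)C(Cc2ccccc2Cl)CN1`, differs from compound 2 at the benzyl group: hydrogen in place of fluoro on an aromatic carbon. Among the measured compounds shown here, no measured pair shows this same change, so its size is open; with the wide spread of compound 1 and the single number of compound 2 as the only guides, a shift no larger than the scatter, or a modest loss, seems the likelier outcome in this assay. Compound 3 is expected at 8000 nM, within 2000 nM to 30000 nM. The step from compound 2 to compound 3 is estimated as a 1.3-fold higher number from compound 2 to compound 3 (0.12 log units; within the scatter).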

Compound 3, half-maximal inhibitory concentration: 21000 nM
For compound 3 the middle estimate is 2.6-fold (0.42 log units) below the measured one, within the range that was stated.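

In this assay, replacing the fluoro with hydrogen, which turns the 2-chloro-6-fluorobenzyl group into 2-chlorobenzyl, gives a 3.5-fold higher number from compound 2 to compound 3 (0.54 log units; beyond the scatter). This is the only single-place step among the compounds shown, and it indicates that the group carried on this aromatic carbon is not a matter of indifference: with hydrogen there, the inhibitor is weaker than with fluoro. The step is modest and rests on a single number for each compound, so it deserves caution, because repeated entries in this series can spread widely, as seen in the several entries of compound 1 in this assay: the several entries of compound 1 in this assay, 1200 nM; 16000 nM; 700 nM (3 entries)

From the compounds shown here alone, how a methyl group, a methoxy group or a nitrile on this same carbon would compare with fluoro remains open. Also open, going by these compounds, is whether the loss seen here would hold with the chloro group replaced by bromo.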